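Swapping an aryl amide for a cyclopentyl amide

The compounds below may be only part of what the source reports. "The series", "measured", "known", "first", "only" and "open" are said of these compounds alone.

Measured compounds:
- compound 1 `N#Cc1cccc(C(=O)NC(=S)N2CCc3c(OCCCCCOc4ccc(Cl)cc4)cccc32)c1`, 9750 nM
- compound 2 `Cc1ccc(C(=O)NC(=S)N2CCc3c(OCCCCCOc4ccc(Cl)cc4)cccc32)cc1`, > 50000 nM
- compound 3 `CC(C)(C)c1ccc(C(=O)NC(=S)N2CCc3c(OCCCCCOc4ccc(Cl)cc4)cccc32)cc1`, > 50000 nM

Three compounds sharing one core were tested in an ADME assay on Huh-7 cells (Homo sapiens) for cytotoxicity; on this read-out lower numbers stand for higher toxicity in this test and higher numbers for lower toxicity in this test. Compound 1 gives 9750 nM. For compound 2 the value of > 50000 nM is a limit of the assay, not a number. For compound 3 the value of > 50000 nM is likewise a limit. The steps of an at least 5.1-fold higher number from compound 1 to compound 2 (0.70 log units; beyond the scatter) and an at least 5.1-fold higher number from compound 1 to compound 3 (0.70 log units; beyond the scatter) both reach that limit; the step that the two limits leave unreadable from compound 2 to compound 3 cannot be read because of the limit of > 50000 nM in this assay, at which 2 of the 3 values shown sit.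

Compound 3 thus stands at the low-toxicity end of what this assay can report, together with compound 2. The next compound, compound 4 `O=C(NC(=S)N1CCc2c(OCCCCCOc3ccc(Cl)cc3)cccc21)C1CCCC1`, differs from compound 3 in one place: cyclopentyl in place of 4-(tert-butyl)phenyl on a carbonyl carbon. Going by the values given here, no measured step changes this part of the molecule in the same way, so the expectation rests on compound 3 alone. The step of a number no higher from compound 3 to compound 4 (the limit leaves the size open) is expected to be small, with compound 4 most likely again reported as a limit.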

Compound 4, half-maximal cytotoxic concentration: > 50000 nM
Compound 4: no number, only a limit; the forecaster's own chance of this, stated with the estimate: 60%; the middle value sits exactly at the limit.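

Until now every group on this carbonyl carbon was a substituted phenyl; in this assay compound 4, which carries a non-aromatic cyclopentyl ring there, also gives a limit of the assay, > 50000 nM. Going by these compounds alone, replacing 3-cyanophenyl with cyclopentyl gives an at least 5.1-fold higher number from compound 1 to compound 4 (0.70 log units; beyond the scatter), so 3-cyanophenyl remains the only group at this place that gives a number rather than a limit. The steps among the compounds at the limit cannot be read because they share this ceiling: the limit of > 50000 nM in this assay, at which 3 of the 4 values shown sit.

As far as these compounds go, what stays open is whether the lower number goes with the nitrile itself or with its place on the phenyl ring. A 4-cyanophenyl group, or a cyclopentyl ring carrying a nitrile, on the same carbonyl carbon would help separate the two.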